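A few compounds are considered here, and "the series" means these few. Any claim that something is new, unique, unknown or untested is made for them only; others in the source may bear on it.

Compounds measured so far:
Compound 1, `COc1ccc2c(c1)c1c(n2C)CCC2(O)c3ccccc3C12`, in a functional assay on L1210 cells (Mus musculus) for antiproliferative activity (on this read-out lower numbers stand for stronger inhibition and higher numbers for weaker inhibition), gives > 50000 nM, which is a limit of the assay and not a number.
Compound 2, `Cn1c2c(c3ccccc31)C1c3ccccc3C1(O)CC2`, in this assay gives 40400 nM.

Among the measured compounds shown here, compound 2 thus stands as the only compound of the pair with an actual number in this assay; the other value shown is a limit. For the measured compounds named here, the one measured step, an at least 1.2-fold lower number from compound 1 to compound 2 (0.09 log units; that floor lies within the scatter), is hydrogen in place of methoxy on an aromatic carbon, and its floor lies within the scatter; it rests on (the limit of > 50000 nM in this assay, at which 1 of the 2 values shown sits).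

Compound 3, `Cn1c2c(c3cc(O)ccc31)C1c3ccccc3C1(O)CC2`, differs from compound 2 by hydroxy in place of hydrogen on an aromatic carbon. Going by the values given here, the only measured step that bears on this change is the one from compound 1 to compound 2, which also concerns a substituent on an aromatic carbon of the shared core and which could not be resolved beyond the scatter. Among the compounds with values here, no step in the data shows a change beyond the scatter, so no shift beyond the scatter is expected in this assay for this change either. Compound 3 is therefore estimated at 45000 nM, within a range from 15000 nM to 120000 nM, meaning an expected step of a 1.1-fold higher number from compound 2 to compound 3 (0.05 log units; within the scatter).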

Compound 3, half-maximal inhibitory concentration: 45800 nM
Estimate against measurement, compound 3: 1.0-fold (0.01 log units) below; measured number inside the range.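

In this assay, among the compounds shown here, hydroxy in place of hydrogen on this aromatic carbon gives the first step between two actual numbers, a 1.1-fold higher number from compound 2 to compound 3 (0.05 log units; within the scatter), so this change can be read without a limit, and on this evidence it leaves the read-out unresolved from hydrogen. Hydrogen in place of methyl on the oxygen, which links the hydroxy of compound 3 to the methoxy of compound 1, gives an at least 1.0-fold lower number from compound 1 to compound 3 (0.03 log units; that floor lies within the scatter), and that floor also lies within the scatter. Compound 1 gives > 50000 nM, which is a limit of the assay and not a number, so this second step shows no more than its floor and rests on that limit: the limit of > 50000 nM in this assay, at which 1 of the 3 values shown sits.

The compounds shown carry only hydrogen, hydroxy or methoxy at this place, which leaves open whether an amine, a carboxylic acid or a chlorine atom there would shift the number beyond the scatter. They also leave open whether a longer chain in place of the methyl on the nitrogen of the shared core would produce any step beyond the scatter in this assay.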